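Series notes: from compound 3 to compound 4

The source may report more compounds than this note shows. Statements on the series, on what has been measured and on what is new or still open speak of the compounds shown alone.

Three measured compounds share one core and differ only at the saturated chain carbon bound to an amide-type nitrogen and a carbonyl carbon. Compound 1 `O=C(CN(c1ncnc2c1ncn2C1CCCCO1)C1CC1)N[C@@H](CCC(=O)OCc1ccccc1)C(=O)OCc1ccccc1` gives 25.2% in a functional assay on the whole organism (Tail, strain ICR) with Mus musculus as the target, in the tail flick test, with a stated time of 90 min, at a dose of 25 umol/kg by the oral route; on this read-out higher numbers stand for a stronger effect at the one dose given and lower numbers for a weaker effect. Compound 2 `O=C(CN(c1ncnc2c1ncn2C1CCCCO1)C1CC1)NCC(=O)OCc1ccccc1` gives 25.9%. Compound 3 `CC[C@H](C)[C@H](NC(=O)CN(c1ncnc2c1ncn2C1CCCCO1)C1CC1)C(=O)OCc1ccccc1` gives 22.6%, the lowest of the three numbers, yet its steps to both others are within the scatter: a number 2.6 percentage points lower from compound 1 to compound 3 (within the scatter) and a number 3.3 percentage points lower from compound 2 to compound 3 (within the scatter); likewise a number 0.7 percentage points higher from compound 1 to compound 2 (within the scatter). Compound 4 `C[C@@H](O)[C@H](NC(=O)CN(c1ncnc2c1ncn2C1CCCCO1)C1CC1)C(=O)OCc1ccccc1` is not yet measured. The change is hydroxy in place of ethyl on a saturated chain carbon bound to two saturated chain carbons. None of the measured steps exchanges ethyl for hydroxy, so no direct precedent exists; the three steps that vary this region of the molecule all lie within the scatter, and nothing in the numbers shown points to a direction. The step of a number 1.4 percentage points higher from compound 3 to compound 4 (within the scatter) is therefore expected to be none beyond the scatter. Compound 4 is estimated at 24%, with a range from 12% to 36%.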

Compound 4, a percentage reported as activity, at one dose (the size of the read-out at that dose, not a potency): 23.4%
For compound 4 the middle estimate is 0.6 percentage points above the measured one, within the range that was stated.
By their numbers in this assay, from the lowest: compounds 3, 4, 1 and 2 (each within the scatter of the next).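

In this assay, hydroxy in place of ethyl on a saturated chain carbon bound to two saturated chain carbons stays within the scatter (a number 0.8 percentage points higher from compound 3 to compound 4 (within the scatter)), so this exchange, which brings in a hydrogen-bond donor and acceptor, gives no readable change at this position. On the saturated chain carbon bound to an amide-type nitrogen and a carbonyl carbon, 1-hydroxyethyl also stays within the scatter of hydrogen (a number 2.5 percentage points lower from compound 2 to compound 4 (within the scatter)) and of 2-(benzyloxycarbonyl)ethyl (a number 1.8 percentage points lower from compound 1 to compound 4 (within the scatter)). No measurement shown here bears on why these numbers lie so close together.

On these data alone, it remains open whether an amine, a carboxylic acid or a longer chain on this carbon would move the number beyond the scatter. The compounds shown also leave open whether their closeness holds at other doses or times.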